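Swapping Isobutyl for Sec-Butyl on a Sulfonamide Anilide

The compounds below may be only part of what the source reports. "The series", "measured", "known", "first", "only" and "open" are said of these compounds alone.

Three compounds share a core in which an amide-type nitrogen carries both a benzoyl group and an arylsulfonyl group. Compound 3 `CC(=O)c1ccc(NC(=O)C(CC(C)C)N(C(=O)c2ccccc2)S(=O)(=O)c2ccc([N+](=O)[O-])cc2)cc1` gives 71% in a functional assay for inhibition, read by spectrophotometry, with a stated time of 20 min, tested at 4 mg/mL (a higher number here means a stronger effect of the compound at the concentration tested, a lower number a weaker effect), the highest of the three numbers measured. Compound 1 `CCC(C)C(C(=O)Nc1ccc(C(C)=O)cc1)N(C(=O)c1ccccc1)S(=O)(=O)c1ccc(C)cc1` gives 41.1% in this assay, and compound 2 `CC(=O)c1ccc(NC(=O)CN(C(=O)c2ccccc2)S(=O)(=O)c2ccc([N+](=O)[O-])cc2)cc1` gives 20.7%.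

For the measured compounds named here, the one measured step that alters the saturated chain carbon bound to an amide-type nitrogen and a carbonyl carbon is a number 50.3 percentage points higher from compound 2 to compound 3 (beyond the scatter), showing that adding a four-carbon branch at this place changed the read-out a great deal.

Compound 4 `CCC(C)C(C(=O)Nc1ccc(C(C)=O)cc1)N(C(=O)c1ccccc1)S(=O)(=O)c1ccc([N+](=O)[O-])cc1` has not yet been measured. It differs from compound 3 by sec-butyl in place of isobutyl on a saturated chain carbon bound to an amide-type nitrogen and a carbonyl carbon. Going by the values given here, no measured step rearranges a branch in this way, so the size of the change can only be guessed. Compound 1 carries the same sec-butyl group and gives 41.1%, while compound 3 with isobutyl gives 71%, though those two compounds also differ elsewhere. A moderate downward step in this assay is therefore expected, with wide uncertainty. Compound 4 is estimated to give 52%, within a range from 30% to 72%. That estimate corresponds to an expected step of a number 19 percentage points lower from compound 3 to compound 4 (beyond the scatter).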

Compound 4, a percentage reported as inhibition, at one concentration (the size of the read-out at that concentration, not a potency): 48.4%
Compound 4: middle estimate off by 3.6 percentage points, on the high side; the measured number falls inside the stated range.
By their numbers in this assay, from the lowest: compound 2; then compounds 1 and 4 (each within the scatter of the next); then compound 3.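

In this assay, moving from isobutyl to sec-butyl on this saturated chain carbon gives a number 22.6 percentage points lower from compound 3 to compound 4 (beyond the scatter), so with the same four carbons, the way they are joined changes the read-out. Both branches beat hydrogen at this place, but sec-butyl in place of hydrogen gives a number 27.7 percentage points higher from compound 2 to compound 4 (beyond the scatter), a smaller gain than a number 50.3 percentage points higher from compound 2 to compound 3 (beyond the scatter) seen with isobutyl. On the aromatic carbon, nitro in place of methyl gives a number 7.3 percentage points higher from compound 1 to compound 4 (within the scatter) and so, with sec-butyl on the chain, these two aromatic groups cannot be told apart in this assay by this read-out.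

No measurement here explains why the arrangement of the branch matters. Still open, going by these compounds, is how a straight butyl chain, a smaller methyl group or a benzyl group would compare at this chain carbon, and whether nitro and methyl would also stay within the scatter of each other with isobutyl in place of sec-butyl.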